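Series notes: loss of the benzyloxycarbonyl group

This account rests on a few compounds, and the source may have more. Where it says the series, first, only, none or still open, it means among the compounds named here.

Three measured compounds share one core. Compound 1 `O=C(OCc1ccccc1)N1CCN(C(=S)SCc2cn(Cc3ccc(Cl)cc3)nn2)CC1` gives in a functional assay on PC-3 cells (Homo sapiens) for inhibition, read by MTT assay, with a stated time of 72 h (on this read-out lower numbers stand for stronger inhibition and higher numbers for weaker inhibition), the assay limit > 128000 nM, not a number. Compound 2 `COc1ccc(Cn2cc(CSC(=S)N3CCN(C(=O)OCc4ccccc4)CC3)nn2)cc1` likewise gives only the limit > 128000 nM in this assay. Compound 3 `Cc1ccc(Cn2cc(CSC(=S)N3CCN(C(=O)OCc4ccccc4)CC3)nn2)cc1` also reaches no number in this assay, only the limit > 128000 nM. Compound 2 therefore stands at the limit, as do the other two, and the limit of > 128000 nM in this assay, at which 3 of the 3 values shown sit, sums up all that this assay has shown so far. The steps among them, a step that the two limits leave unreadable from compound 1 to compound 2, a step that the two limits leave unreadable from compound 1 to compound 3 and a step that the two limits leave unreadable from compound 2 to compound 3, cannot be read in size or direction.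

Compound 4 `COc1ccc(Cn2cc(CSC(=S)N3CCNCC3)nn2)cc1` differs from compound 2 by hydrogen in place of benzyloxycarbonyl on an amine nitrogen in a ring. For the measured compounds named here, no measured step touches this ring nitrogen, so nothing here tells what to expect beyond the shared limit. The step from compound 2 to compound 4 in this assay is expected to be an at least 1.0-fold lower number from compound 2 to compound 4 (0.02 log units; that floor lies within the scatter), with no direction supported. Compound 4 is estimated at 120000 nM in this assay, within 30000 nM to 400000 nM, and most probably again only a limit.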

Compound 4, half-maximal inhibitory concentration: > 128000 nM
Compound 4 gave a limit, no number (the forecaster's own chance of this, stated with the estimate: 70%); middle value at least 1.0-fold (0.02 log units) from the limit.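

In this assay compound 4 gives > 128000 nM as a limit, not a number. For the compounds shown here, with compound 2 also at a limit, no step between compound 2 and compound 4 can be read. The compounds shown leave open whether any change on the shared core yields a measurable value: the limit of > 128000 nM in this assay, at which 4 of the 4 values shown sit.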